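Swapping one side group on compound 1

The source may report more compounds than this note shows. Statements on the series, on what has been measured and on what is new or still open speak of the compounds shown alone.

For the measured compounds named here, in a functional assay on U-373MG ATCC cells for inhibition, with U373 MG (Homo sapiens) as the target, read by MTT assay, with a stated time of 7 days (a lower number here means a stronger inhibitor of growth, a higher number a weaker inhibitor of growth), compound 1 (`C[Si](C)(C)CCOCn1nnc2c(C(N)=O)ncn2c1=O`) gives 25300 nM as the only exact number so far. In this assay compound 2 (`COc1ccc(Cn2nnc3c(C(N)=O)ncn3c2=O)cc1`) gives > 50000 nM as its result, and this is a limit rather than a number.

Compound 3 (`Cc1noc(Cn2nnc3c(C(N)=O)ncn3c2=O)n1`) keeps the core of compound 1 and changes a single group: a group of 6 heavy atoms (3 carbon, 2 nitrogen, 1 oxygen; one five-membered aromatic ring with 3 hetero atoms) in place of a group of 7 heavy atoms (5 carbon, 1 oxygen, 1 silicon; no ring), on a saturated chain carbon bound to an aromatic nitrogen (a ring-bearing group replaces an open chain). Going by the values given here, no measured pair shows this exact change, so the prediction has only a thin base. The firmest anchor is compound 1 at 25300 nM in this assay, and a step no larger than the scatter is expected, leaning towards weaker growth inhibition. The estimated change is a 1.6-fold higher number from compound 1 to compound 3 (0.20 log units; within the scatter) as the likely outcome. For compound 3 the expected value is 40000 nM within an estimated range of 15000 nM to 100000 nM overall.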

Compound 3, concentration for 50% growth inhibition: > 50000 nM
Compound 3 was reported as a limit; the forecaster's own chance of this, stated with the estimate: 50%; middle value at least 1.2-fold (0.09 log units) from the limit.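

In this assay compound 3 is reported only as a limit, > 50000 nM. Putting 3-methyl-1,2,4-oxadiazol-5-yl in place of the open chain, on a saturated chain carbon bound to an aromatic nitrogen, gives an at least 1.9-fold higher number from compound 1 to compound 3 (0.29 log units; that floor lies within the scatter), so this ring-bearing group shows no gain in growth inhibition, while a real loss is not established either. The true size of the step stays unknown because the reading stops at a limit: the limit of > 50000 nM in this assay, at which 2 of the 3 values shown sit.

Compound 1 gives 25300 nM. From the compounds shown here alone, it remains open whether another group at this place, such as a longer alkyl chain, a primary amine or a carboxylic acid, would bring the number lower than that of compound 1. Also open, going by these compounds, is whether the silicon in compound 1 matters, which an open chain with carbon in its place could test.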